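The compounds below may be only part of what the source reports. "The series", "measured", "known", "first", "only" and "open" are said of these compounds alone.

Measured so far:
compound 1 `O=C(CSc1ccccc1)N1N=C(c2cc3ccccc3oc2=O)C[C@@H]1c1ccccc1`: 22800 nM
compound 2 `O=C(CSc1ccc([N+](=O)[O-])cc1)N1N=C(c2cc3ccccc3oc2=O)C[C@@H]1c1ccccc1C(F)(F)F`: 7580 nM

In a functional assay on MGC-803 cells (Homo sapiens) for cytotoxicity, read by MTT assay, with a stated time of 48 h (a higher number here means a weaker inhibitor, a lower number a stronger inhibitor), compound 1 has the higher of the two numbers, at 22800 nM. Compound 2 is lower, at 7580 nM, a gap beyond the scatter. Compound 1 is therefore the weaker inhibitor of this pair.

The next compound is compound 3 `CCCCSCC(=O)N1N=C(c2cc3ccccc3oc2=O)C[C@@H]1c1ccccc1`, which differs from compound 1 as follows: butyl in place of phenyl on a sulfur. Going by the values given here, no measured pair shows a change at this place, so the expectation rests only on the value of compound 1 and carries wide bounds. A small move towards a higher number is expected, possibly none beyond the scatter, and the estimated step is a 1.1-fold higher number from compound 1 to compound 3 (0.06 log units; within the scatter). For compound 3 the estimated value is 26000 nM, with an expected range of 9000 nM to 75000 nM.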

Compound 3, half-maximal inhibitory concentration: 12900 nM
Compound 3: middle estimate off by 2.0-fold (0.30 log units), on the high side; measured number inside the range.
By their numbers in this assay, from the lowest: compounds 2, 3 and 1 (each within the scatter of the next, the first and the last beyond it).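

In this assay butyl in place of phenyl on a sulfur gives a 1.8-fold lower number from compound 1 to compound 3 (0.25 log units; within the scatter) and so stays within the usual scatter. At this position in this assay, the six-membered aromatic ring of compound 1 is therefore not needed to keep a value of the same order, since compound 3 carries an open chain with no ring. No measurement available here bears on why this exchange leaves the value within the scatter.

The compounds shown leave open whether a longer chain, a cyclohexyl ring, an amine or a carboxylic acid on the sulfur would move the value beyond the scatter. From the compounds shown here alone, compound 2 differs from compound 1 in more than one place, so the separate contribution of each of its changes also remains open.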